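The source may hold more compounds than are shown below. What is called first, only, known or untested is meant among the compounds shown, and "the series" means these compounds.

Notes on the series. Among the three measured compounds only one entry carries a value, and that value is a limit. Compound 1 `OC[C@H]1O[C@@H](n2cnc3c(NCc4ccc(F)cc4)ncnc32)[C@H](O)[C@@H]1O` in a functional assay on G-361 cells (Homo sapiens) for antiproliferative activity, with a stated time of 72 h (on this read-out higher numbers stand for weaker inhibition and lower numbers for stronger inhibition), reaches only the limit > 166000 nM. Among the compounds with values here, the sole evidence is the limit of > 166000 nM in this assay, at which 1 of the 3 values shown sits, with no number behind it. Compound 2 `COc1cccc(CNc2ncnc3c2ncn3[C@@H]2O[C@H](CO)[C@@H](O)[C@H]2O)c1` has "not determined" (no result reported) in this assay. Compound 3 `COc1cccc(CNc2ncnc3c2ncn3[C@@H]2O[C@H](CO)[C@@H](O)[C@H]2O)c1OC` likewise has "not determined" (no result reported) in this assay. Within the data shown here, no step between two measured compounds can be read, so compound 1 stands alone at the limit, with nothing to rank it against.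

Compound 4 `OC[C@H]1O[C@@H](n2cnc3c(NCc4cccc(O)c4O)ncnc32)[C@H](O)[C@@H]1O` differs from compound 1 in one place: 2,3-dihydroxyphenyl in place of 4-fluorophenyl on a saturated chain carbon bound to a nitrogen on an aromatic ring. Cut one bond further out, 4-fluorobenzyl becomes 2,3-dihydroxybenzyl. Among the measured compounds shown here, no measured step in this assay bears on this change, so what is expected rests on the limit of compound 1 alone. The step expected in this assay is an at least 3.3-fold lower number from compound 1 to compound 4 (0.52 log units; beyond the scatter), a gain beyond the scatter, though a limit may again be all that is reported. Compound 4 is estimated at 50000 nM in this assay, within 8000 nM to 166000 nM.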

Compound 4, half-maximal inhibitory concentration: 16900 nM
The estimate for compound 4 lay 3.0-fold (0.47 log units) above the measured number; measured number inside the range.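

The series now has its first number in this assay, which shows that this read-out responds to the group on a saturated chain carbon bound to a nitrogen on an aromatic ring. Changing 4-fluorobenzyl to 2,3-dihydroxybenzyl gives an at least 9.8-fold lower number from compound 1 to compound 4 (0.99 log units; beyond the scatter). The full size of this step remains unknown because its starting point is a limit and not a number: the limit of > 166000 nM in this assay, at which 1 of the 4 values shown sits.

The change removes the fluorine and adds two hydroxyl groups in one step, so the compounds shown do not separate the two, and steps involving compound 2 or compound 3 cannot be read. From the compounds shown here alone, it remains open how a benzyl group carrying a single hydroxyl, an amine or a carboxylic acid would compare with the 2,3-dihydroxybenzyl group of compound 4.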